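Cytotoxicity notes: removing the ethyl group from compound 2

The source may hold more compounds than are shown below. What is called first, only, known or untested is meant among the compounds shown, and "the series" means these compounds.

The series is read in a functional assay on HepG2 cells (Homo sapiens) for cytotoxicity, read by MTT assay; on this read-out higher numbers stand for lower toxicity in this test and lower numbers for higher toxicity in this test. Compound 1 `O=c1[nH]c(=O)n(COCCO)cc1[N+](=O)[O-]` gives > 432000 nM in this assay, and this is a limit of the assay rather than a number. Compound 2 `CCc1cn(COCCO)c(=S)[nH]c1=O` gives > 478000 nM in this assay, again a limit and not a measured value. Among the compounds with values here, both values shown thus sit at limits, as recorded by the limit of > 432000 nM in this assay, at which 1 of the 2 values shown sits, and (the limit of > 478000 nM in this assay, at which 1 of the 2 values shown sits), so no step between measured compounds can be drawn, and compound 2 stands at the upper edge of what this assay reports, with nothing to rank it against compound 1.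

Compound 3 `O=c1ccn(COCCO)c(=S)[nH]1` has not yet been measured. It differs from compound 2 by hydrogen in place of ethyl on an aromatic carbon. Within the data shown here, with no measured step available and both neighbours at limits, no change beyond the scatter is expected in this assay. The expected step is a step that the limit leaves unreadable from compound 2 to compound 3. Compound 3 is therefore estimated at 500000 nM, within a range from 200000 nM to 1500000 nM, and is most likely to be reported again only as a limit.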

Compound 3, half-maximal cytotoxic concentration: > 495000 nM
Compound 3: no number, only a limit; the forecaster's own chance of this, stated with the estimate: 85%; the middle value is on the limit's open side.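

In this assay compound 3 gives > 495000 nM, which is a limit and not a number. Within the data shown here, compound 2 also stands only at a limit, and no step from it to compound 3 can be read. The compounds shown leave open whether hydrogen in place of ethyl on an aromatic carbon changes the read-out, and at what concentration any of them would turn cytotoxic.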